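Sec-butyl for isobutyl on the nitrogen

The source may hold more compounds than are shown below. What is called first, only, known or untested is meant among the compounds shown, and "the series" means these compounds.

- Compound 1 `CC(C)C/N=c1\c(O)c(O)\c1=N/Cc1ccc(C#N)cc1` gives 10200 nM
- Compound 2 `CC(C)(C)/N=c1\c(O)c(O)\c1=N/Cc1ccc(Cl)cc1Cl` gives 1300 nM

In a functional assay for inhibition, with Rattus norvegicus as the target (on this read-out higher numbers stand for weaker inhibition and lower numbers for stronger inhibition), compound 1 stands highest of the two numbers, and compound 2 lies lower by a margin beyond the scatter. Compound 3 `CC[C@H](C)/N=c1\c(O)c(O)\c1=N/Cc1ccc(C#N)cc1` differs from compound 1 as follows: sec-butyl in place of isobutyl on a double-bonded nitrogen with sec-butyl in place of isobutyl on a double-bonded nitrogen. Among the measured compounds shown here, no measured pair isolates this change: compound 2 differs from compound 1 in more than one place. In this assay a small move to a lower number is expected, not beyond the scatter. The expected step is a 1.7-fold lower number from compound 1 to compound 3 (0.23 log units; within the scatter) and it remains an estimate. For compound 3 the estimated value is 6000 nM with an expected range from 2000 nM to 15000 nM in this assay for now.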

Compound 3, half-maximal inhibitory concentration: 2200 nM
The estimate for compound 3 lay 2.7-fold (0.44 log units) above the measured number; measured number inside the range.
By their numbers in this assay, from the lowest: compounds 2 and 3 (each within the scatter of the next); then compound 1.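

In this assay, sec-butyl in place of isobutyl on a double-bonded nitrogen gives a 4.6-fold lower number from compound 1 to compound 3 (0.67 log units; beyond the scatter). Among the compounds shown here, this is the first single-place comparison, and it shows that this position responds to a rearrangement of the chain alone, with the heavy-atom count unchanged and the rest of compound 1 kept. No measurement at hand accounts for the step. The mirror-image sec-butyl group leaves open whether the defined stereocentre matters. A longer chain such as n-pentyl, or a cyclopropylmethyl group, would show how far this position tolerates change.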